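Extending the hydroxycarbamoyl chain: compound 3 to compound 4

This account rests on a few compounds, and the source may have more. Where it says the series, first, only, none or still open, it means among the compounds named here.

- compound 1 `O=C(/C=C/c1ccc(CN(Cc2ccc(F)cc2)c2ncc(C(=O)NCCCn3ccnc3)s2)cc1)NO`: 2700 nM
- compound 2 `CC(C)CCN(CCCCCCC(=O)NO)c1ncc(C(=O)NCCCn2ccnc2)s1`: 5200 nM
- compound 3 `O=C(CCCCCN(Cc1ccc(F)cc1)c1ncc(C(=O)NCCCn2ccnc2)s1)NO`: 54000 nM
- compound 4 `O=C(CCCCCCN(Cc1ccc(F)cc1)c1ncc(C(=O)NCCCn2ccnc2)s1)NO`: not yet measured

In a functional assay on A549 cells (Homo sapiens) for inhibition, read by MTT assay, with a stated time of 72 h (on this read-out higher numbers stand for weaker inhibition and lower numbers for stronger inhibition), compound 3 has the highest number of the three, 54000 nM, which makes it the weakest. Compound 1 and compound 2 lie within the scatter of each other.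

The next change is (hydroxycarbamoyl)methyl in place of hydroxycarbamoyl on a saturated chain carbon, five bonds along the chain from a nitrogen on an aromatic ring. In words, (hydroxycarbamoyl)methyl stands in place of hydroxycarbamoyl on a saturated chain carbon, five bonds along the chain from a nitrogen on an aromatic ring.

Within the data shown here, no measured step isolates this change. Among the measured compounds shown here, the only step available is a 20-fold higher number from compound 1 to compound 3 (1.30 log units; beyond the scatter), a large one, in which 4-(hydroxycarbamoyl)butyl replaces 4-(2-(hydroxycarbamoyl)ethenyl)phenyl. It shows that this arm can move the number substantially, but says nothing directly about chain length. The chain of compound 4 has the same length as that of compound 2, which carries a different second group on the nitrogen and gives 5200 nM. That value points towards a lower number, though the different group leaves this uncertain.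

In this assay the expected change is a 6.0-fold lower number from compound 3 to compound 4 (0.78 log units; beyond the scatter), a sizeable step to a lower number. The estimate for compound 4 is 9000 nM, with an expected range of 2500 nM to 30000 nM.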

Compound 4, half-maximal inhibitory concentration: 9700 nM
Estimate against measurement, compound 4: 1.1-fold (0.03 log units) below; the measured number falls inside the stated range.
By their numbers in this assay, from the lowest: compounds 1, 2 and 4 (each within the scatter of the next, the first and the last beyond it); then compound 3.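

Notes on the series: in this assay, (hydroxycarbamoyl)methyl in place of hydroxycarbamoyl on the saturated chain carbon gives a 5.6-fold lower number from compound 3 to compound 4 (0.75 log units; beyond the scatter), the first direct evidence that the length of this chain affects the number, while 4-fluorophenyl in place of isobutyl gives a 1.9-fold higher number from compound 2 to compound 4 (0.27 log units; within the scatter), so that exchange does not separate the two compounds at this chain length. The 5-(hydroxycarbamoyl)pentyl arm recovers much of the loss seen in a 20-fold higher number from compound 1 to compound 3 (1.30 log units; beyond the scatter), but a gap to the 4-(2-(hydroxycarbamoyl)ethenyl)phenyl arm remains, as a 3.6-fold higher number from compound 1 to compound 4 (0.56 log units; beyond the scatter) shows. Nothing available gives a measured reason for these shifts.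

With only the 4-(hydroxycarbamoyl)butyl and 5-(hydroxycarbamoyl)pentyl arms compared on the 4-fluorophenyl series, the compounds shown leave open whether a longer chain, such as 6-(hydroxycarbamoyl)hexyl, would lower the number further or reverse the trend. They also leave open whether the hydroxycarbamoyl end is needed at all, which a carboxylic acid at the end of the same chain would test.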